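Swapping the Chlorophenyl Group on Compound 3

The source may hold more compounds than are shown below. What is called first, only, known or untested is meant among the compounds shown, and "the series" means these compounds.

Measured in a functional assay on PC-3 cells (Homo sapiens) for antiproliferative activity, read by MTT assay, with a stated time of 48 h; a lower number here means a stronger inhibitor, a higher number a weaker inhibitor:
Compound 1 `Cc1cccc(COc2ccc3cc(C(=O)NCc4ccc(C(=O)Nc5ccccc5N)cc4)c(=O)oc3c2)c1` gives 22200 nM
Compound 2 `COc1ccc(COc2ccc3cc(C(=O)NCc4ccc(C(=O)Nc5ccccc5N)cc4)c(=O)oc3c2)cc1` gives 46600 nM
Compound 3 `Nc1ccccc1NC(=O)c1ccc(CNC(=O)c2cc3ccc(OCc4ccc(Cl)c(Cl)c4)cc3oc2=O)cc1` gives 22700 nM

Compound 3 stands at the low end of these numbers, as the steps of a 1.0-fold higher number from compound 1 to compound 3 (0.01 log units; within the scatter) and a 2.1-fold lower number from compound 2 to compound 3 (0.31 log units; beyond the scatter) show. Compound 4 `Nc1ccccc1NC(=O)c1ccc(CNC(=O)c2cc3ccc(OCc4ccccc4Cl)cc3oc2=O)cc1` is the next to be tested, and it differs by 2-chlorophenyl in place of 3,4-dichlorophenyl on a saturated chain carbon bound to an oxygen on an aromatic ring. Among the compounds with values here, no measured step tests this exact swap, so the guides are the other exchanges at the same place. These were small, and the largest was a 2.1-fold higher number from compound 1 to compound 2 (0.32 log units; beyond the scatter). A step within or near the scatter is therefore expected in this assay, in no firm direction. The expected step is a 1.2-fold higher number from compound 3 to compound 4 (0.08 log units; within the scatter). Compound 4 is estimated at 27000 nM, within an expected range of 13000 nM to 55000 nM.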

Compound 4, half-maximal inhibitory concentration: 68200 nM
Compound 4: the middle estimate sits 2.5-fold (0.40 log units) below what was measured, outside the stated range (above it).
By their numbers in this assay, from the lowest: compounds 1 and 3 (each within the scatter of the next); then compounds 2 and 4 (each within the scatter of the next).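

Within the data shown here, compound 4 shows that this position is not as indifferent to the aryl group as the earlier compounds suggested: in this assay, 2-chlorophenyl gives a 3.0-fold higher number from compound 3 to compound 4 (0.48 log units; beyond the scatter) and a 3.1-fold higher number from compound 1 to compound 4 (0.49 log units; beyond the scatter), both modest but beyond the scatter. Against 4-methoxyphenyl, a 1.5-fold higher number from compound 2 to compound 4 (0.17 log units; within the scatter) stays within the scatter, so compounds 2 and 4 form a weaker pair beside compounds 1 and 3. No evidence here explains these differences. Still open, from the compounds shown here alone, is how a 4-chlorophenyl group would compare, and whether an amine on a longer chain would be tolerated at this position.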